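Linker shortening in the retinoid ester series

A few compounds are considered here, and "the series" means these few. Any claim that something is new, unique, unknown or untested is made for them only; others in the source may bear on it.

Compound 1 `CCCC(=O)OCCCCOC(=O)c1ccc(C(=O)Nc2ccc3c(c2)C(C)(C)CCC3(C)C)cc1` gives 23200 nM in a functional assay on NB-4 cells (Homo sapiens) for inhibition, read by MTT assay, with a stated time of 48 h; on this read-out lower numbers stand for stronger inhibition and higher numbers for weaker inhibition. Compound 2 `CCCC(CCC)C(=O)OCCCOC(=O)c1ccc(C(=O)Nc2ccc3c(c2)C(C)(C)CCC3(C)C)cc1` reaches only a limit of the assay, > 1000000 nM, in this assay (the limit of > 1000000 nM in this assay, at which 1 of the 2 values shown sits). Going by the values given here, the sole measured step, an at least 43-fold higher number from compound 1 to compound 2 (1.63 log units; beyond the scatter), altered the acyl part together with the chain, so it bears only loosely on the present change. Compound 3 `CCCC(CCC)C(=O)OCCOC(=O)c1ccc(C(=O)Nc2ccc3c(c2)C(C)(C)CCC3(C)C)cc1` carries ((1-propylbutyl)carbonyl)oxy in place of (((1-propylbutyl)carbonyl)oxy)methyl on a saturated chain carbon, two bonds along the chain from an oxygen next to a carbonyl group. The step from compound 2 is expected to be small, an at least 1.6-fold lower number from compound 2 to compound 3 (0.22 log units; that floor lies within the scatter). Compound 3 is therefore estimated at 600000 nM, with a range from 100000 nM to 3000000 nM, and may again be reported only as a limit.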

Compound 3, half-maximal inhibitory concentration: > 1000000 nM
Compound 3 gave a limit, no number; the forecaster's own chance of this, stated with the estimate: 55%; middle value at least 1.6-fold (0.22 log units) away from the limit.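

In this assay compound 3 gives > 1000000 nM, a limit and not a number. The change from (((1-propylbutyl)carbonyl)oxy)methyl to ((1-propylbutyl)carbonyl)oxy cannot be read, with limits at both ends, and it brings no return to a measurable value with this acyl part. The series now shows an at least 43-fold higher number from compound 1 to compound 3 (1.63 log units; beyond the scatter) with the shorter chain too, and the ceiling covers more of the set: the limit of > 1000000 nM in this assay, at which 2 of the 3 values shown sit.

The compounds shown do not separate the acyl part from the chain as the source of this large step. Also open, as far as these compounds go, is whether a propylcarbonyl ester on the shorter chain, or a terminal hydroxyl or carboxylic acid, would come off the limit in this assay.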